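Moving the trifluoromethyl group around the terminal phenyl ring

The source may report more compounds than this note shows. Statements on the series, on what has been measured and on what is new or still open speak of the compounds shown alone.

Measured compounds:
Compound 1 `COc1cc(NC(C)CCCNC(=O)NNC(=O)Nc2cc(C(F)(F)F)cc(C(F)(F)F)c2)c2ncccc2c1` — 18000 nM
Compound 2 `COc1cc(NC(C)CCCNC(=O)Nc2ccc(C(F)(F)F)cc2)c2ncccc2c1` — 24000 nM
Compound 3 `COc1cc(NC(C)CCCNC(=O)NNC(=O)Nc2cccc(C(F)(F)F)c2)c2ncccc2c1` — 20000 nM

All three values come from a functional assay on NCI-H460 cells (Homo sapiens) for inhibition, read by MTT assay, with a stated time of 72 h; on this read-out higher numbers stand for weaker inhibition and lower numbers for stronger inhibition. Compound 3 stands second highest of the three numbers, with compound 1 and compound 2 each within the scatter of it. Among the measured compounds shown here, the one measured step, a 1.1-fold higher number from compound 1 to compound 3 (0.05 log units; within the scatter), is within the scatter.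

Compound 4 `COc1cc(NC(C)CCCNC(=O)NNC(=O)Nc2ccc(C(F)(F)F)cc2)c2ncccc2c1` differs from compound 3 by 4-(trifluoromethyl)phenyl in place of 3-(trifluoromethyl)phenyl on an amide-type nitrogen. For the measured compounds named here, no measured step covers this change; compound 2 carries the same 4-(trifluoromethyl)phenyl group on a different linker, and its value and that of compound 3 sit within the scatter of each other. The step of no change at the digits printed from compound 3 to compound 4 (within the scatter) is therefore expected to stay within the scatter. Compound 4 is estimated at 20000 nM, in the range 10000 nM to 40000 nM.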

Compound 4, half-maximal inhibitory concentration: 12000 nM
For compound 4 the middle estimate is 1.7-fold (0.22 log units) above the measured one; the range from low to high includes it.
By their numbers in this assay, from the lowest: compounds 4, 1, 3 and 2 (each within the scatter of the next).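

In this assay, exchanging 3-(trifluoromethyl)phenyl for 4-(trifluoromethyl)phenyl on the amide-type nitrogen gives a 1.7-fold lower number from compound 3 to compound 4 (0.22 log units; within the scatter). Among the compounds shown here, this is the first direct reading of where the trifluoromethyl group sits on the ring with this linker, and the shift stays within the usual scatter, as did the loss of a trifluoromethyl group in the earlier step. Nothing available here offers an explanation for the step. The compounds shown leave open whether an amine or a carboxylic acid in place of trifluoromethyl would carry the number beyond the scatter.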